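Aryl ether variation at the shared core: compounds 1 to 4

A few compounds are considered here, and "the series" means these few. Any claim that something is new, unique, unknown or untested is made for them only; others in the source may bear on it.

Measured so far in a functional assay on CHO cells for agonist activity at Free fatty acid receptor 1 (Homo sapiens), read by FLIPR and calcium flux, tested at 1 uM; a lower number here means that less compound is needed, a higher number that more compound is needed for the effect:
- compound 1 `O=C(O)CCc1ccc(NC(=O)c2nnc(COc3ccc(F)cc3)s2)cc1` gives 5390 nM
- compound 2 `O=C(O)CCc1ccc(NC(=O)c2nnc(COc3ccc4c(c3)CCC4)s2)cc1` gives 1380 nM
- compound 3 `O=C(O)CCc1ccc(NC(=O)c2nnc(COc3cccc(Cl)c3)s2)cc1` gives 1570 nM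

Compound 3 holds the second highest of the three numbers. Its nearest neighbour is compound 2: the step of a 1.1-fold higher number from compound 2 to compound 3 (0.06 log units; within the scatter) lies within the scatter, so the two cannot be ordered. Its furthest neighbour is compound 1, from which the step of a 3.4-fold lower number from compound 1 to compound 3 (0.54 log units; beyond the scatter) is a modest improvement.

Compound 4 `Cc1ccc(OCc2nnc(C(=O)Nc3ccc(CCC(=O)O)cc3)s2)c(C)c1` differs from compound 3 only at the ether: 2,4-dimethylphenyl in place of 3-chlorophenyl on an oxygen on a saturated carbon. Two of the measured steps bear on this position. Replacing the 4-fluorophenyl of compound 1 gave a 3.9-fold lower number from compound 1 to compound 2 (0.59 log units; beyond the scatter) and a 3.4-fold lower number from compound 1 to compound 3 (0.54 log units; beyond the scatter), both modest and in the same direction. The exchange of one such aryl group for another, a 1.1-fold higher number from compound 2 to compound 3 (0.06 log units; within the scatter), stayed within the scatter. On that basis the substituted phenyl groups other than 4-fluorophenyl cluster together, and the move to 2,4-dimethylphenyl is expected to give a step of a 1.0-fold higher number from compound 3 to compound 4 (0.01 log units; within the scatter) that stays within the scatter, in no settled direction. For compound 4 the expected value in this assay is 1600 nM, within a range from 700 nM to 3600 nM.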

Compound 4, half-maximal effective concentration: 2540 nM
Compound 4: middle estimate off by 1.6-fold (0.20 log units), on the low side, within the range that was stated.
By their numbers in this assay, from the lowest: compounds 2, 3 and 4 (each within the scatter of the next); then compound 1.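

In this assay, 2,4-dimethylphenyl joins the cluster of aryl groups on this ether: the steps to it from 3-chlorophenyl (a 1.6-fold higher number from compound 3 to compound 4 (0.21 log units; within the scatter)) and from 2,3-dihydro-1H-inden-5-yl (a 1.8-fold higher number from compound 2 to compound 4 (0.26 log units; within the scatter)) both stay within the scatter, so compounds 2, 3 and 4 cannot be ordered. The step from 4-fluorophenyl (a 2.1-fold lower number from compound 1 to compound 4 (0.33 log units; beyond the scatter)) is a third modest one in the same direction, which leaves compound 1 apart from all three others and extends the cluster to a group carrying two substituents on its phenyl ring. No measurement here bears on why these three aryl groups sit together or why 4-fluorophenyl stands apart.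

Open at this ether is whether a pyridine ring, or a phenyl ring carrying a methoxy group, a nitrile or an amine, would stay inside the same cluster or move the number clearly away from it. Open elsewhere on the shared core is what a longer chain to the carboxylic acid, or a tetrazole in place of that acid, would do to the number.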